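Halogen swap on compound 2: bromo to fluoro

The compounds below may be only part of what the source reports. "The series", "measured", "known", "first", "only" and "open" are said of these compounds alone.

Working notes on the series. Compound 1 `Cc1c(O)ccc2c1[C@H](Cn1cc(-c3ccc(F)cc3)nn1)[C@@]13CC(=O)[C@@](C)(CC[C@@H]21)C3`, compound 2 `C=C1C[C@]23C[C@@]1(O)CC[C@@H]2c1cccc(C)c1[C@@H]3Cn1cc(-c2ccc(Br)cc2)nn1`, compound 3 `C=C1C(=O)[C@]23C[C@@]1(O)CC[C@H]2c1ccc(O)c(C)c1[C@@H]3Cn1cc(-c2ccc(C)cc2)nn1` and the unmeasured compound 4 `C=C1C[C@]23C[C@@]1(O)CC[C@@H]2c1cccc(C)c1[C@@H]3Cn1cc(-c2ccc(F)cc2)nn1` share a core and differ in the substituent on the pendant phenyl and in the core itself. In a functional assay on SW480 cells (Homo sapiens) for cytotoxicity, read by MTT assay, with a stated time of 4 days (a lower number here means a stronger inhibitor, a higher number a weaker inhibitor), compound 2 gives only a limit, > 20000 nM. Compound 1 likewise gives only a limit, > 20000 nM. Compound 3 gives 330 nM. Compound 2 therefore stands at the limit of > 20000 nM in this assay, at which 2 of the 3 values shown sit, without a number of its own. Compound 4 differs from compound 2 by fluoro in place of bromo on an aromatic carbon. Within the data shown here, no measured step covers this change. Compound 1, which also carries the 4-fluorophenyl, sits at the limit > 20000 nM, so no shift beyond the scatter is expected. The step that the limit leaves unreadable from compound 2 to compound 4 is expected to be essentially none. Compound 4 is estimated at 30000 nM, in the range 8000 nM to 100000 nM.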

Compound 4, half-maximal inhibitory concentration: > 20000 nM
Compound 4 ended at the assay's limit; the forecaster's own chance of this, stated with the estimate: 70%; the middle value lies beyond the limit too.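

In this assay, compound 2 and compound 4 both sit at a limit of the assay, and no step can be read between them. The compounds shown leave open whether 4-bromophenyl to 4-fluorophenyl shifts potency at all on this core.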